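The source may hold more compounds than are shown below. What is called first, only, known or untested is meant among the compounds shown, and "the series" means these compounds.

Measured in a functional assay on NCI-H1975 cells (Homo sapiens) for antiproliferative activity, read by CCK-8 assay, with a stated time of 72 h; a lower number here means a stronger inhibitor of growth, a higher number a weaker inhibitor of growth:
Compound 1 `CCC1C(=O)N(C)c2cnc(Nc3ccc(S(=O)(=O)NCC(C)C)cc3)nc2N1c1ccn(C)n1`: 15000 nM
Compound 2 `CCC1C(=O)N(C)c2cnc(-n3ccc4cc(C(=O)NC)ccc43)nc2N1c1ccn(C)n1`: 35700 nM

Compound 2 has the higher number of the two, and its gap to compound 1 lies beyond the scatter. Compound 3 `CCC1C(=O)N(C)c2cnc(-n3ccc4cc(C(=O)NCC(C)C)ccc43)nc2N1c1ccn(C)n1` differs from compound 2 in one place: isopropyl in place of hydrogen on a saturated chain carbon bound to an amide-type nitrogen. Within the data shown here, no measured pair shows this change alone. Compound 1, at 15000 nM, also carries an isobutyl group, though on a different scaffold, so at most a small move towards a lower number in this assay is expected, not one beyond the scatter. The expected step is a 1.8-fold lower number from compound 2 to compound 3 (0.25 log units; within the scatter). For compound 3 the estimate is 20000 nM, within an expected range of 7000 nM to 50000 nM.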

Compound 3, concentration for 50% growth inhibition: 10200 nM
Compound 3: middle estimate off by 2.0-fold (0.29 log units), on the high side, and the stated range covers the measured number.
By their numbers in this assay, from the lowest: compounds 3 and 1 (each within the scatter of the next); then compound 2.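

In this assay, going from methylcarbamoyl to isobutylcarbamoyl gives a 3.5-fold lower number from compound 2 to compound 3 (0.54 log units; beyond the scatter), a modest step but one beyond the scatter. Among these compounds, this shows that the group on this amide-type nitrogen affects growth inhibition, which the earlier compounds could not show, as they differ in more than one place. Nothing measured here gives a reason for the step. On these data alone, whether an ethyl group, a longer chain or a chain carrying an amine would do better at this place remains open.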